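This account rests on a few compounds, and the source may have more. Where it says the series, first, only, none or still open, it means among the compounds named here.

Of the compounds shown here, three built on one shared core have been tested in a functional assay on SGC-7901 cells (Homo sapiens) for cytotoxicity, read by MTT assay, with a stated time of 48 h; on this read-out higher numbers stand for weaker inhibition and lower numbers for stronger inhibition. Compound 1 `CC(C)(C)c1ccc(Cn2cc(COc3ccc4c(=O)ccoc4c3)nn2)cc1` reaches only the limit of the measurement, > 100000 nM. Compound 2 `O=c1ccoc2cc(OCc3cn(Cc4ccccc4Cl)nn3)ccc12` likewise gives a limit rather than a number, > 100000 nM. Compound 3 `C#CCOc1ccc2c(=O)ccoc2c1` also gives a limit, > 100000 nM. Compound 2 thus stands exactly where every value shown stands, at the limit of > 100000 nM in this assay, at which 3 of the 3 values shown sit, so there is no number to rank it against. Compound 4 `N#Cc1cccc(Cn2cc(COc3ccc4c(=O)ccoc4c3)nn2)c1` differs from compound 2 in one place: 3-cyanophenyl in place of 2-chlorophenyl on a saturated chain carbon bound to an aromatic nitrogen. Because all three values shown sit at the limit of > 100000 nM in this assay, at which 3 of the 3 values shown sit, no change beyond the usual scatter is expected in this assay for this exchange. The expected step is a number no higher from compound 2 to compound 4 (the limit leaves the size open). Compound 4 is therefore estimated at 100000 nM, between 30000 nM and 300000 nM, most likely again reported only as a limit.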

Compound 4, half-maximal inhibitory concentration: > 100000 nM
Compound 4 gave a limit, no number; the forecaster's own chance of this, stated with the estimate: 85%; the middle value sits exactly at the limit.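

Compound 2 and compound 4 each give only a limit, so no step can be read between them: the limit of > 100000 nM in this assay, at which 4 of the 4 values shown sit. The compounds shown leave open whether any group on the shared core gives a real number in this assay at all.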